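The compounds below may be only part of what the source reports. "The series", "measured", "known", "first", "only" and "open" are said of these compounds alone.

Among the measured compounds shown here, compound 1 `COc1cc(-c2cc(/C=C/C(=O)c3ccc(N)cc3)[nH]n2)cc(OC)c1OC` is one of two compounds measured so far in a functional assay on MDA-MB-435 cells (Homo sapiens) for inhibition, read by sulforhodamine B assay, with a stated time of 48 h; a higher number here means a weaker inhibitor of growth, a lower number a stronger inhibitor of growth. In this assay compound 1 gives 1660 nM. For the measured compounds named here, the only other measured compound, compound 2 `COc1ccc(-c2cc(/C=C/C(=O)c3ccc(OC)c(OC)c3)[nH]n2)cc1`, gives 1840 nM in this assay, a number so close to that of compound 1 that the two lie within the usual scatter of repeated measurements and cannot be told apart. Compound 2 differs from compound 1 in more than one place, so no single structural step can be read between them.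

Compound 3 `COc1cc(-c2cc(/C=C/C(=O)c3ccc(Cl)c(Cl)c3)[nH]n2)cc(OC)c1OC` has not yet been measured. It differs from compound 1 in one place: 3,4-dichlorophenyl in place of 4-aminophenyl on a carbonyl carbon. The rest of the molecule, the shared core with its trimethoxyphenyl group, is unchanged.

Going by the values given here, no measured step between two compounds in this set differs in a single place, so there is no directly comparable precedent. The step of a 1.2-fold higher number from compound 1 to compound 3 (0.08 log units; within the scatter) is therefore expected to be small, no larger than the scatter, with no clear direction. Compound 3 is expected to give about 2000 nM in this assay, within a range from 700 nM to 6000 nM.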

Compound 3, concentration for 50% growth inhibition: 5650 nM
Estimate against measurement, compound 3: 2.8-fold (0.45 log units) below; the measured number falls inside the stated range.
By their numbers in this assay, from the lowest: compounds 1 and 2 (each within the scatter of the next); then compound 3.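

Among the compounds shown here, this is the first comparison in the set that changes a single place, and it shows that the group on the carbonyl carbon matters in this assay: 3,4-dichlorophenyl in place of 4-aminophenyl gives a 3.4-fold higher number from compound 1 to compound 3 (0.53 log units; beyond the scatter) and so a weaker inhibitor of growth, a modest step that lies beyond the scatter. The change removes the hydrogen-bond donor and acceptor counted on 4-aminophenyl and brings in two chlorine atoms, so several things differ at once and this one step cannot separate them. Nothing measured here explains the step through a property of either group.

From the compounds shown here alone, it remains open whether the step follows the loss of the amine or the arrival of the chlorine atoms, a question that plain phenyl or 4-chlorophenyl at this place could help to settle. Going by these compounds, it is also open whether an acetamide or a carboxylic acid in place of the amine would stay close to compound 1 or move as far as compound 3 did.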